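Dimethylamino in place of methoxy on the benzylamine of compound 3

A few compounds are considered here, and "the series" means these few. Any claim that something is new, unique, unknown or untested is made for them only; others in the source may bear on it.

Compound 1, `O=C(CCCNCc1ccccc1)N1CCN(C(c2ccccc2)c2ccc(Cl)cc2)CC1`, in an assay on HEK293 cells for inhibition of Voltage-dependent T-type calcium channel subunit alpha-1G (Homo sapiens), read by patch clamp; on this read-out lower numbers stand for stronger inhibition and higher numbers for weaker inhibition: 1670 nM
Compound 2, `O=C(CCCNCc1ccc([N+](=O)[O-])cc1)N1CCN(C(c2ccccc2)c2ccc(Cl)cc2)CC1`, in this assay: 600 nM
Compound 3, `COc1ccc(CNCCCC(=O)N2CCN(C(c3ccccc3)c3ccc(Cl)cc3)CC2)cc1`, in this assay: 16100 nM

Compound 3 stands highest of the three measured numbers, the weakest inhibitor of the set. The change from compound 1 gave a 9.6-fold higher number from compound 1 to compound 3 (0.98 log units; beyond the scatter), and the change from compound 2 gave a 27-fold higher number from compound 2 to compound 3 (1.43 log units; beyond the scatter); for comparison, the step of a 2.8-fold lower number from compound 1 to compound 2 (0.44 log units; beyond the scatter) went the other way.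

Compound 4, `CN(C)c1ccc(CNCCCC(=O)N2CCN(C(c3ccccc3)c3ccc(Cl)cc3)CC2)cc1`, is not yet measured. It differs from compound 3 by dimethylamino in place of methoxy on an aromatic carbon. For the measured compounds named here, none of the three measured steps involves a dimethylamino group; the only evidence about this position is that a methoxy group there raised the number well beyond the scatter, while a nitro group lowered it modestly. From the compounds shown here alone, the measured series therefore gives no direct guidance on what a dimethylamino group does, and both directions remain open. In the absence of a matching precedent, compound 4 is expected to stay in the region of compound 3, with a 1.3-fold lower number from compound 3 to compound 4 (0.13 log units; within the scatter) as the estimated step. Compound 4 is estimated at 12000 nM in this assay, in a wide range from 3000 nM to 40000 nM.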

Compound 4, half-maximal inhibitory concentration: 2320 nM
For compound 4 the middle estimate is 5.2-fold (0.71 log units) above the measured one, outside the stated range (below it).
By their numbers in this assay, from the lowest: compound 2; then compounds 1 and 4 (each within the scatter of the next); then compound 3.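

Replacing methoxy with dimethylamino on the aromatic carbon para to a large group gives a 6.9-fold lower number from compound 3 to compound 4 (0.84 log units; beyond the scatter) in this assay, although both groups carry no hydrogen-bond donors and one hydrogen-bond acceptor, so that count alone does not set the number at this place. Dimethylamino in place of hydrogen gives a 1.4-fold higher number from compound 1 to compound 4 (0.14 log units; within the scatter) and so cannot be told apart from the plain benzylamine, while dimethylamino in place of nitro gives a 3.9-fold higher number from compound 2 to compound 4 (0.59 log units; beyond the scatter); among these four compounds, only methoxy and nitro stand clear of hydrogen, on opposite sides of it. Nothing shown here explains why methoxy and dimethylamino part so widely at this carbon.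

It remains open how other groups on this carbon, such as a primary amine, a hydroxyl, a chlorine or a carboxylic acid, would place themselves among these four numbers. From the compounds shown here alone, it is also open whether dimethylamino and methoxy would keep this same order on another carbon of the ring or with a longer chain in place of the present one.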